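A few compounds are considered here, and "the series" means these few. Any claim that something is new, unique, unknown or untested is made for them only; others in the source may bear on it.

Measured in a functional assay on PC-3 cells (Homo sapiens) for antiproliferative activity, read by MTT assay, with a stated time of 48 h; a higher number here means a weaker inhibitor, a lower number a stronger inhibitor:

- Compound 1 `O=C(CCCCCC(=O)Nc1nnc(-c2cccs2)s1)NO`: > 60000 nM (a limit)
- Compound 2 `O=C(CCCCCC(=O)Nc1nnc(-c2cccnc2)s1)NO`: 54400 nM
- Compound 3 `O=C(CCCCCCC(=O)Nc1nnc(-c2ccncc2)s1)NO`: 7750 nM

Compound 1 is known only through its limit of > 60000 nM. Of the two actual numbers in this assay, the higher belongs to compound 2, at 54400 nM, and compound 3 lies clearly below it, beyond the scatter.

The next compound is compound 4 `O=C(CCCCCCC(=O)Nc1nnc(-c2cccnc2)s1)NO`. It is made from compound 2 by one change to the chain: (hydroxycarbamoyl)methyl in place of hydroxycarbamoyl on a saturated chain carbon, five bonds along the chain from a carbonyl carbon. In words, (hydroxycarbamoyl)methyl stands in place of hydroxycarbamoyl on a saturated chain carbon, five bonds along the chain from a carbonyl carbon.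

Going by the values given here, the only measured single change is an at least 1.1-fold lower number from compound 1 to compound 2 (0.04 log units; that floor lies within the scatter). That step concerns the aromatic group, not the chain, so it says little here. Among the compounds with values here, no measured step isolates the chain change. Within the data shown here, the one hint is compound 3 at 7750 nM, the only measured compound with a chain as long as that of compound 4, though its aromatic group is not the same. A lower number in this assay is therefore expected, beyond the scatter but with wide uncertainty. The expected change is a 4.2-fold lower number from compound 2 to compound 4 (0.62 log units; beyond the scatter). Compound 4 is estimated at 13000 nM, with an expected range from 4500 nM to 42000 nM.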

Compound 4, half-maximal inhibitory concentration: 7980 nM
Compound 4: middle estimate off by 1.6-fold (0.21 log units), on the high side, and the stated range covers the measured number.
By their numbers in this assay, from the lowest: compounds 3 and 4 (each within the scatter of the next); then compound 2. At a limit, above all of these: compound 1.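

In this assay, going by these compounds alone, (hydroxycarbamoyl)methyl in place of hydroxycarbamoyl on a saturated chain carbon, five bonds along the chain from a carbonyl carbon, gives a 6.8-fold lower number from compound 2 to compound 4 (0.83 log units; beyond the scatter), the first measured step at this place, and it shows that the chain alone moves the number beyond the scatter while pyridin-3-yl stays fixed. With the chain of compound 4 held constant, the aromatic group can also be compared directly, and pyridin-3-yl in place of pyridin-4-yl gives a 1.0-fold higher number from compound 3 to compound 4 (0.01 log units; within the scatter), so these two groups are not told apart on this chain. Nothing measured here gives a cause for the chain step.

As far as these compounds go, it remains open whether the lower number continues with 2-(hydroxycarbamoyl)ethyl or a still longer chain, and whether a carboxylic acid in place of the hydroxycarbamoyl end would keep it. From the compounds shown here alone, compound 1 stands only as a limit, > 60000 nM, and how thiophen-2-yl behaves on the chain of compound 4 also remains open.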